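A sulfonamide nitrogen loses its 1,3-thiazol-2-yl group

The source may hold more compounds than are shown below. What is called first, only, known or untested is meant among the compounds shown, and "the series" means these compounds.

In a functional assay on HT-29 cells (Homo sapiens) for antiproliferative activity, read by sulforhodamine B assay, with a stated time of 72 h (on this read-out higher numbers stand for weaker inhibition and lower numbers for stronger inhibition), compound 1 `CCN1C(=O)CS/C1=N/Nc1nncc2ccccc12` gives 58 nM, compound 3 `O=C1CS/C(=N/Nc2nncc3ccccc23)N1` gives 49 nM, and compound 2 `O=S(=O)(Nc1nccs1)c1ccc(Nc2nncc3ccccc23)cc1` gives 34 nM. Compound 2 has the lowest number of the three, yet it stays within the scatter of both others, so the three cannot be ranked.

The next compound is compound 4 `NS(=O)(=O)c1ccc(Nc2nncc3ccccc23)cc1`, which carries hydrogen in place of 1,3-thiazol-2-yl on a sulfonamide nitrogen.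

Within the data shown here, only one measured step offers any guidance: a 1.2-fold lower number from compound 1 to compound 3 (0.07 log units; within the scatter), with hydrogen in place of ethyl on an amide-type nitrogen in a ring. That step lies within the scatter, but it involves a different group on a different nitrogen. Among the measured compounds shown here, no measured pair tests the loss of 1,3-thiazol-2-yl itself, so the guidance is indirect and the range must stay wide.

Going by these compounds, no step beyond the scatter is therefore expected in this assay, and the direction remains open. The estimated step is a 1.3-fold higher number from compound 2 to compound 4 (0.12 log units; within the scatter). The expected value for compound 4 is 45 nM, with an estimated range of 12 nM to 170 nM.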

Compound 4, half-maximal inhibitory concentration: 12 nM
Beside the measured number, compound 4's estimate is 3.8-fold (0.57 log units) above it; measured number inside the range.
By their numbers in this assay, from the lowest: compound 4; then compounds 2, 3 and 1 (each within the scatter of the next).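

In this assay, among these compounds, the loss of the 1,3-thiazol-2-yl group from the sulfonamide nitrogen gives a 2.8-fold lower number from compound 2 to compound 4 (0.45 log units; beyond the scatter) and so becomes the first step here to lie beyond the scatter, since the only earlier step, on a different nitrogen, stayed within it. The sulfonamide nitrogen is therefore a place where the group matters on this read-out, and there hydrogen gives the lower number, though the step is only modest. Nothing measured here bears on why the number falls.

Going by these compounds, it remains open whether a methyl or acetyl group on this nitrogen would read like hydrogen or like 1,3-thiazol-2-yl. The compounds shown also leave open how a carboxylic acid in place of the whole sulfonamide would read.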